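The source may hold more compounds than are shown below. What is called first, only, known or untested is meant among the compounds shown, and "the series" means these compounds.

Measured compounds:
- compound 1, `CCCN(CCC)c1ccc(Nc2ncc(Cl)c(Oc3cccc(NC(=O)CC)c3)n2)cc1`: 9.3%
- compound 2, `CCC(=O)Nc1cccc(Oc2nc(Nc3ccc(N4CCC(C)CC4)cc3OC)ncc2Cl)c1`: 9.2%
- compound 3, `CCCN(CCC)c1ccc(Nc2ncc(Cl)c(Oc3cccc(NC(=O)CC)c3)n2)c(OC)c1`: "not active" (no number reported)

In an assay on isolated protein for inhibition of NUAK family SNF1-like kinase 1 (Homo sapiens), read by ADP-Glo, with a stated time of 60 min, tested at 10 uM, in the presence of a further agent that is not named here (a lower number here means less inhibition, a higher number more inhibition at the concentration tested (going by the name of the read-out)), compound 1 gives 9.3%. Compound 2 gives 9.2% in this assay, a number only slightly lower than that of compound 1 and within the usual scatter, so the two cannot be told apart. Compound 3 was reported as not active in this assay without a number. On the numbers shown, compound 1 therefore has the higher of two values, but neither compound inhibits the enzyme to any notable degree at the concentration tested.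

Compound 4, `CCC(=O)Nc1cccc(Oc2nc(Nc3ccc(N4CCCC4)cc3)ncc2Cl)c1`, has not yet been measured in this assay. It differs from compound 1 in one place: pyrrolidin-1-yl in place of dipropylamino on an aromatic carbon. For the measured compounds named here, no step between measured compounds of this kind is known here. Both compound 1 and compound 2 give low inhibition, so the expectation is that this change makes a step of no meaningful size, and the number for compound 4 is expected to stay low, with a number 0.7 percentage points higher from compound 1 to compound 4 (within the scatter) falling within the scatter. Compound 4 is estimated to give 10% in this assay, expected to lie between 0% and 25%.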

Compound 4, a percentage reported as inhibition, at one concentration (the size of the read-out at that concentration, not a potency): "not active" (no number reported)
No number was reported for compound 4; no gap can be computed for the estimate.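

Compound 4 was reported as not active in this assay with no number, so no step can be read between it and compound 1, which gives 9.3% in the same test. Nothing measured here offers an explanation for this result. The compounds shown leave open whether replacing dipropylamino with pyrrolidin-1-yl changes inhibition at all.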